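The source may hold more compounds than are shown below. What is called first, only, known or untested is meant among the compounds shown, and "the series" means these compounds.

The measured compounds:
compound 1 `CC1CCN(c2c(S(=O)(=O)c3ccc(C#N)cc3)cnc3cc(Cl)ccc23)CC1`, which in an assay on isolated protein for displacement of a labelled ligand from metabotropic glutamate receptor 5 (Homo sapiens), with a stated time of 60 min, tested at 1 uM (on this read-out lower numbers stand for less inhibition and higher numbers for more inhibition at the one concentration tested (going by the name of the read-out)), gives 70%;
compound 2 `CC1CCN(c2c(S(=O)(=O)c3ccc(C#N)cc3)cnc3cc(F)ccc23)CC1`, which in this assay gives 83%.

Compound 1 stands lowest of the two numbers; its nearest neighbour is compound 2, and the step of a number 13 percentage points higher from compound 1 to compound 2 (beyond the scatter) comes with fluoro in place of chloro on an aromatic carbon. Compound 3 `Cc1ccc(S(=O)(=O)c2cnc3cc(Cl)ccc3c2N2CCC(C)CC2)cc1C` has not yet been measured. It differs from compound 1 in one place: 3,4-dimethylphenyl in place of 4-cyanophenyl on a sulfonyl sulfur, a change on a sulfonyl sulfur whose other neighbour is an aromatic carbon. For the measured compounds named here, no measured step touches this part of the shared core; the only known step, that between compound 1 and compound 2, concerns a different part of the molecule and offers no guide here. The expectation for this assay is therefore open, with no direction favoured beyond the scatter, and a wide range is kept. Compound 3 is estimated at 60% (range 30% to 85%). The expected step is a number 10 percentage points lower from compound 1 to compound 3 (within the scatter).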

Compound 3, a percentage reported as inhibition, at one concentration (the size of the read-out at that concentration, not a potency): 86%
The estimate for compound 3 lay 26 percentage points below the measured number; the whole stated range lies below it.
By their numbers in this assay, from the lowest: compound 1; then compounds 2 and 3 (each within the scatter of the next).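

In this assay, for the compounds shown here, the first change at the sulfonyl sulfur shows that this position responds to its aryl group: 3,4-dimethylphenyl in place of 4-cyanophenyl gives a number 16 percentage points higher from compound 1 to compound 3 (beyond the scatter). The nitrile is therefore not required for this level of inhibition at the one concentration tested, since an all-carbon aromatic group on the sulfonyl sulfur serves at least as well in this pair. Nothing available explains the difference between the two groups.

As far as these compounds go, it remains open whether one methyl group alone would give the same result, and how a methoxy group or an amine on the phenyl ring would read out. Also open, from the compounds shown here alone, is whether fluoro in place of chloro, which raised the number in the 4-cyanophenyl series, would have any effect alongside 3,4-dimethylphenyl.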